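The compounds below may be only part of what the source reports. "The series", "measured", "known", "first", "only" and "open" are said of these compounds alone.

Compound 1 `CC1=NN(c2ccc(C)cc2)C(=O)C12C=CC(=O)C=C2c1ccc(C)cc1` gives 5110 nM in a functional assay on MDA-MB-231 cells (Homo sapiens) for antiproliferative activity, read by CCK-8 assay, with a stated time of 72 h; on this read-out lower numbers stand for stronger inhibition and higher numbers for weaker inhibition.
Compound 2 `CC1=NN(c2ccc(C)cc2)C(=O)C12C=CC(=O)C=C2c1ccccc1` gives 46600 nM in this assay.

Compound 2 stands highest of these two numbers; its nearest neighbour is compound 1, and the move between them is a 9.1-fold higher number from compound 1 to compound 2 (0.96 log units; beyond the scatter). Compound 3 `CC1=NN(c2ccc(Cl)cc2)C(=O)C12C=CC(=O)C=C2c1ccccc1` differs from compound 2 in one place: chloro in place of methyl on an aromatic carbon. Within the data shown here, the only measured step, a 9.1-fold higher number from compound 1 to compound 2 (0.96 log units; beyond the scatter), concerns a different group at another place, so no measured step bears on this swap. With nothing to point either way, no step beyond the scatter is expected in this assay. Compound 3 is therefore estimated at 35000 nM, between 10000 nM and 120000 nM. The expected step is a 1.3-fold lower number from compound 2 to compound 3 (0.12 log units; within the scatter).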

Compound 3, half-maximal inhibitory concentration: > 100000 nM
Compound 3 gave a limit, no number; the forecaster's own chance of this, stated with the estimate: 10%; middle value at least 2.8-fold (0.45 log units) away from the limit.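

In this assay the change from 4-methylphenyl to 4-chlorophenyl gives an at least 2.1-fold higher number from compound 2 to compound 3 (0.33 log units; beyond the scatter) and so shows that this second place on the shared core also matters, with the exchange of a single heavy atom enough to weaken inhibition. Going by these compounds, compound 3 gives > 100000 nM as a limit and not a number, so the true size of this step stays unknown: the limit of > 100000 nM in this assay, at which 1 of the 3 values shown sits.

On these data alone, whether any group other than methyl weakens inhibition here remains open. A fluoro, a methoxy or an amine at this position would help to show that.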